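From acetyl to ethoxycarbonyl in a cell toxicity series

The compounds below may be only part of what the source reports. "The series", "measured", "known", "first", "only" and "open" are said of these compounds alone.

compound 1 `COc1ccc(/C=C(\C#N)C(=O)N/N=C(\C)c2cc3cccc(OC)c3oc2=O)cc1OC`: 3300 nM
compound 2 `COc1cc(/C=C(\C#N)C(=O)N/N=C(\C)c2cc3cccc(OC)c3oc2=O)cc(OC)c1OC`: 11100 nM
compound 3 `COc1cccc2cc(-c3ccc(C(C)=O)c(C)n3)c(=O)oc12`: 354000 nM

In a toxicity assay on WI-38 cells (Homo sapiens) for cytotoxicity, read by MTT assay, with a stated time of 48 h (a lower number here means a stronger inhibitor, a higher number a weaker inhibitor), compound 3 stands highest of the three at 354000 nM, making it the weakest inhibitor here. Compound 4 `CCOC(=O)c1ccc(-c2cc3cccc(OC)c3oc2=O)nc1C` has ethoxy in place of methyl on a carbonyl carbon, turning acetyl into ethoxycarbonyl: ethoxy in place of methyl on a carbonyl carbon. Among the compounds with values here, no measured step tests this change directly. Within the data shown here, the only single-change step, a 3.4-fold higher number from compound 1 to compound 2 (0.53 log units; beyond the scatter), is methoxy in place of hydrogen on an aromatic carbon, and it offers only a rough sense of size. The expected shift, a 1.8-fold lower number from compound 3 to compound 4 (0.25 log units; within the scatter), is small and leans towards a lower number, possibly staying within the scatter. For compound 4 the estimated value is 200000 nM, with an expected range of 60000 nM to 500000 nM.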

Compound 4, half-maximal inhibitory concentration: 67700 nM
The estimate for compound 4 lay 3.0-fold (0.47 log units) above the measured number; the measured number falls inside the stated range.
By their numbers in this assay, from the lowest: compound 1; then compound 2; then compound 4; then compound 3.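

Turning acetyl into ethoxycarbonyl in this assay gives a 5.2-fold lower number from compound 3 to compound 4 (0.72 log units; beyond the scatter) and so moves the number beyond the scatter. This shows that the group on this carbonyl carbon matters to the read-out, even though the whole change stays on one side chain of the shared core. Compound 4 remains a weaker inhibitor here than compound 1 and compound 2 by its printed value.

From the compounds shown here alone, whether a carboxylic acid, an amide or a longer chain in place of ethoxy would lower the number further remains open. Nothing shown here explains why this swap moved the number.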